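A few compounds are considered here, and "the series" means these few. Any claim that something is new, unique, unknown or untested is made for them only; others in the source may bear on it.

Compound 1 `c1ccc2c(-c3cnc4[nH]nc(-c5nc6ccccc6[nH]5)c4c3)cncc2c1` gives 1700 nM in a functional assay on HeLa cells (Homo sapiens) for antiproliferative activity; a lower number here means a stronger inhibitor, a higher number a weaker inhibitor. Compound 2 `Cc1cccc2[nH]c(-c3n[nH]c4ncc(-c5cncc6ccccc56)cc34)nc12`, which carries a methyl in place of hydrogen on an aromatic carbon, gives 3090 nM; the change is a 1.8-fold higher number from compound 1 to compound 2 (0.26 log units; within the scatter). Compound 3 `CC(C)NCc1cccc2[nH]c(-c3n[nH]c4ncc(-c5cncc6ccccc56)cc34)nc12` gives 130 nM, the lowest of the three numbers. Compound 4 `CCN(CC)C(=O)c1cccc2[nH]c(-c3n[nH]c4ncc(-c5cncc6ccccc56)cc34)nc12` is not yet measured; it differs from compound 3 by diethylcarbamoyl in place of (isopropylamino)methyl on an aromatic carbon. For the measured compounds named here, the steps that bear on this are the ones that brought the (isopropylamino)methyl group in, a 13-fold lower number from compound 1 to compound 3 (1.12 log units; beyond the scatter) and a 24-fold lower number from compound 2 to compound 3 (1.38 log units; beyond the scatter), both large. Taking that group away again is expected to undo much of the gain, so a large step toward a higher number is expected, a 12-fold higher number from compound 3 to compound 4 (1.06 log units; beyond the scatter). Compound 4 is estimated at 1500 nM, in a range from 400 nM to 6000 nM.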

Compound 4, half-maximal inhibitory concentration: 170 nM
Beside the measured number, compound 4's estimate is 8.8-fold (0.95 log units) above it; measured number outside the range, below it.
By their numbers in this assay, from the lowest: compounds 3 and 4 (each within the scatter of the next); then compounds 1 and 2 (each within the scatter of the next).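

In this assay the exchange of (isopropylamino)methyl for diethylcarbamoyl on this aromatic carbon gives a 1.3-fold higher number from compound 3 to compound 4 (0.12 log units; within the scatter) and so stays within the scatter: a group with a carbonyl serves as well as one with an amine. Compared with the methyl and the hydrogen, the new group gives an 18-fold lower number from compound 2 to compound 4 (1.26 log units; beyond the scatter) and a 10-fold lower number from compound 1 to compound 4 (1.00 log units; beyond the scatter), so the lower number here is not tied to (isopropylamino)methyl alone. Nothing measured here explains why these two groups give such similar numbers.

The compounds shown leave open whether a carboxylic acid, a piperidine amide or a longer chain at this place would keep the lower number.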